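A few compounds are considered here, and "the series" means these few. Any claim that something is new, unique, unknown or untested is made for them only; others in the source may bear on it.

In a functional assay on HeLa cells (Homo sapiens) for antiproliferative activity, read by MTT assay, with a stated time of 72 h (on this read-out lower numbers stand for stronger inhibition and higher numbers for weaker inhibition), compound 1 (`CCn1ccnc1-c1cc(OC)c(OC)c(OC)c1`) stands at a limit, not a number: > 100000 nM. Compound 2 (`COc1cc(-c2nccn2S(=O)(=O)c2ccccc2)cc(OC)c1OC`) also gives only a limit, > 100000 nM. These two compounds make up (the limit of > 100000 nM in this assay, at which 2 of the 3 values shown sit). Compound 4 (`COc1cc(-c2nccn2-c2ccc(C)cc2)cc(OC)c1OC`) departs from compound 1 by one change: 4-methylphenyl in place of ethyl on an aromatic nitrogen. Going by the values given here, compound 3 (`COc1cc(-c2nccn2-c2ccc3sccc3c2)cc(OC)c1OC`), which also carries an aromatic group on that nitrogen, gives 1400 nM, the only true number in the set, and this value is the basis for expecting a real gain in potency beyond the scatter. The expected size of that gain is uncertain, and the estimated step is an at least 20-fold lower number from compound 1 to compound 4 (1.30 log units; beyond the scatter). Compound 4 is estimated at 5000 nM, with an expected range of 800 nM to 50000 nM.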

Compound 4, half-maximal inhibitory concentration: 700 nM
Compound 4: middle estimate off by 7.1-fold (0.85 log units), on the high side; measured number below the stated range.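

Placing 4-methylphenyl in place of ethyl on this aromatic nitrogen gives an at least 140-fold lower number from compound 1 to compound 4 (2.15 log units; beyond the scatter) in this assay. This single change is the first shown to carry a compound from a limit to a true number, so this position clearly responds to the group it bears. The step has no fixed size because compound 1 gives only a limit: the limit of > 100000 nM in this assay, at which 2 of the 4 values shown sit.

Open, from the compounds shown here alone, is whether a longer chain such as butyl or a benzyl group would also bring activity at this nitrogen. Also open, going by these compounds, is what the methyl contributes, which plain phenyl could show.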